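Shortening the chain on the nitro-bearing analogue

The compounds below may be only part of what the source reports. "The series", "measured", "known", "first", "only" and "open" are said of these compounds alone.

Compound 1 `Cc1ccc2nc(NC(=O)CCCCCCC(=O)NO)sc2c1` gives 1.6 ug/mL in a functional assay on MCF7 cells (Homo sapiens) for cytotoxicity; a higher number here means a weaker inhibitor, a lower number a stronger inhibitor. Compound 2 `Cc1ccc2nc(NC(=O)CCCCC(=O)NO)sc2c1` differs from compound 1 by hydroxycarbamoyl in place of 2-(hydroxycarbamoyl)ethyl on a saturated chain carbon, four bonds along the chain from a carbonyl carbon. In this assay compound 2 gives 4.27 ug/mL, so that a 2.7-fold higher number from compound 1 to compound 2 (0.43 log units; beyond the scatter). Compound 3 `O=C(CCCCCCC(=O)Nc1nc2ccc([N+](=O)[O-])cc2s1)NO` stands on a different core, the difference from compound 1 being (nitro in place of methyl on an aromatic carbon); compound 3 gives 3.83 ug/mL in this assay, so that a 2.4-fold higher number from compound 1 to compound 3 (0.38 log units; beyond the scatter). Compound 4 `O=C(CCCCC(=O)Nc1nc2ccc([N+](=O)[O-])cc2s1)NO` has not been measured. It differs from compound 3 by hydroxycarbamoyl in place of 2-(hydroxycarbamoyl)ethyl on a saturated chain carbon, four bonds along the chain from a carbonyl carbon, the same change that leads from compound 1 to compound 2 and at the same place. Going by the values given here, the step from compound 3 to compound 4 is expected to be a 2.6-fold higher number from compound 3 to compound 4 (0.42 log units; beyond the scatter), resting on a 2.7-fold higher number from compound 1 to compound 2 (0.43 log units; beyond the scatter) as the only example of this change. For compound 4 the estimate is 10 ug/mL, with a range from 5 ug/mL to 22 ug/mL.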

Compound 4, half-maximal inhibitory concentration: > 30 ug/mL
Compound 4: a limit, no number (the forecaster's own chance of this, stated with the estimate: 5%); at least 3.0-fold (0.47 log units) between middle value and limit.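

In this assay, going by these compounds, compound 4 gives > 30 ug/mL, which is a limit of the assay and not a number, so the true size of the steps to it remains unknown. Hydroxycarbamoyl in place of 2-(hydroxycarbamoyl)ethyl on the nitro-bearing core gives an at least 7.8-fold higher number from compound 3 to compound 4 (0.89 log units; beyond the scatter), a larger step than on the methyl-bearing core: the same change on two cores in this assay, a 2.7-fold higher number (0.43 log units; beyond the scatter) from compound 1 to compound 2 and an at least 7.8-fold higher number (0.89 log units; beyond the scatter) from compound 3 to compound 4, at least 2.9-fold (0.46 log units) apart, beyond the scatter of two such steps

Nitro in place of methyl with the shorter chain gives an at least 7.0-fold higher number from compound 2 to compound 4 (0.84 log units; beyond the scatter), again larger than the earlier step: the same change on two cores in this assay, a 2.4-fold higher number (0.38 log units; beyond the scatter) from compound 1 to compound 3 and an at least 7.0-fold higher number (0.84 log units; beyond the scatter) from compound 2 to compound 4, at least 2.9-fold (0.46 log units) apart, beyond the scatter of two such steps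

The compounds shown leave open whether an amine or a methoxy group in place of nitro would show the same larger chain-shortening step. They also leave open how a longer chain would behave on either core.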